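Working notes: compound 2 to compound 3 in this assay

The source may hold more compounds than are shown below. What is called first, only, known or untested is meant among the compounds shown, and "the series" means these compounds.

Measured so far:
- compound 1 `CCc1ccc2ncn(-c3ccnc(N)n3)c2c1` — 79400 nM
- compound 2 `C=CC(=O)NCC#Cc1ccc2ncn(-c3ccnc(N)n3)c2c1` — 6310 nM

In an assay on Sf9 cells for inhibition of mitogen-activated protein kinase kinase kinase 14 variant S549D (Homo sapiens), with a stated time of 30 min, in the presence of a further agent that is not named here (on this read-out higher numbers stand for weaker inhibition and lower numbers for stronger inhibition), compound 1 gives 79400 nM. Compound 2 gives 6310 nM in this assay. Among the compounds with values here, the single measured step is a 13-fold lower number from compound 1 to compound 2 (1.10 log units; beyond the scatter). Within the data shown here, on these two numbers compound 2 stands lowest; its only neighbour is compound 1, higher by that step.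

Compound 3 `C#Cc1cccc(C#Cc2ccc3ncn(-c4ccnc(N)n4)c3c2)n1` has not been measured in this assay. It differs from compound 2 by a group of 8 heavy atoms (7 carbon, 1 nitrogen; one six-membered aromatic ring with 1 hetero atom) in place of a group of 6 heavy atoms (4 carbon, 1 nitrogen, 1 oxygen; no ring), on a triple-bonded carbon. Among the measured compounds shown here, no measured pair bears directly on this exchange: the step from compound 1 to compound 2 installs the entire 3-((vinylcarbonyl)amino)prop-1-yn-1-yl at once, so it does not separate the triple-bonded linkage that compound 3 keeps from the ((vinylcarbonyl)amino)methyl that leaves. On these data alone, whether the lower number of compound 2 comes from the part kept or the part removed is unknown.

The expectation for compound 3 is therefore cautious: a step of a 1.9-fold higher number from compound 2 to compound 3 (0.28 log units; within the scatter) toward a somewhat higher number, with a wide range. Compound 3 is estimated at 12000 nM, between 2500 nM and 60000 nM.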

Compound 3, half-maximal inhibitory concentration: 3160 nM
Compound 3: the middle estimate sits 3.8-fold (0.58 log units) above what was measured; the range from low to high includes it.
By their numbers in this assay, from the lowest: compounds 3 and 2 (each within the scatter of the next); then compound 1.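

In this assay, the group of 8 heavy atoms on the triple-bonded carbon in place of ((vinylcarbonyl)amino)methyl gives a 2.0-fold lower number from compound 2 to compound 3 (0.30 log units; within the scatter), so the two groups cannot be told apart on this read-out. This position therefore tolerates a substantial exchange without a change beyond the scatter: the carbonyl, the amide hydrogen and both double bonds outside aromatic rings leave, while a six-membered aromatic ring with 1 hetero atom and a further triple bond enter, so the level of this pair does not depend on the ((vinylcarbonyl)amino)methyl itself. No supporting measurement is available to account for this equivalence.

Still open, on these data alone, is how much of this level belongs to the triple-bonded linkage that both compounds keep, which a small group such as hydroxymethyl or dimethylaminomethyl on the triple-bonded carbon would help to separate from the larger groups compared here. Also open, as far as these compounds go, is what each part of the entering group contributes, including its further triple bond, and whether a carboxylic acid or a longer alkyl chain at this place would stay at the same level.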